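The source may hold more compounds than are shown below. What is called first, only, known or untested is meant among the compounds shown, and "the series" means these compounds.

Measured compounds:
compound 1 `COc1ccc(/C=N/NC(=S)NC(C)(C)[C@H]2CC=C(C)CC2)cc1` — 22500 nM
compound 2 `CC1=CC[C@H](C(C)(C)NC(=S)N/N=C/c2ccc(O)cc2)CC1` — a limit, > 100000 nM
compound 3 `CC1=CC[C@H](C(C)(C)NC(=S)N/N=C/c2cccc(Cl)c2)CC1` — 1400 nM

In a functional assay on NCI-H460 cells (Homo sapiens) for inhibition, read by sulforhodamine B assay, with a stated time of 48 h (on this read-out lower numbers stand for stronger inhibition of growth and higher numbers for weaker inhibition of growth), compound 3 gives 1400 nM, the lowest of the two numbers; the nearest is compound 1 at 22500 nM, with a 16-fold lower number from compound 1 to compound 3 (1.21 log units; beyond the scatter) between them. For compound 2 only a limit is recorded, > 100000 nM (the limit of > 100000 nM in this assay, at which 1 of the 3 values shown sits). The step to compound 4 `CC1=CC[C@H](C(C)(C)NC(=S)N/N=C/c2cccs2)CC1` is thiophen-2-yl in place of 3-chlorophenyl on a carbon with a double bond to nitrogen. The two measured steps that also exchange the group on that carbon are a 16-fold lower number from compound 1 to compound 3 (1.21 log units; beyond the scatter) and an at least 71-fold lower number from compound 2 to compound 3 (1.85 log units; beyond the scatter), both large; the remaining step, an at least 4.4-fold higher number from compound 1 to compound 2 (0.64 log units; beyond the scatter), changes a substituent on the aromatic ring instead. Within the data shown here, no measured step puts a five-membered ring in that place, so the direction cannot be read directly; the measured steps show only that the group on that carbon moves this assay strongly. Compound 4 is expected near 4000 nM (range 1200 nM to 14000 nM), a modest expected move, a 2.9-fold higher number from compound 3 to compound 4 (0.46 log units; beyond the scatter), toward a higher number, with wide uncertainty.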

Compound 4, concentration for 50% growth inhibition: 10800 nM
Beside the measured number, compound 4's estimate is 2.7-fold (0.43 log units) below it, within the range that was stated.
By their numbers in this assay, from the lowest: compound 3; then compound 4; then compound 1. At a limit, above all of these: compound 2.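

In this assay, the carbon with a double bond to nitrogen now carries a five-membered aromatic ring, and thiophen-2-yl falls well short of 3-chlorophenyl, with a 7.7-fold higher number from compound 3 to compound 4 (0.89 log units; beyond the scatter) as the step. Thiophen-2-yl still improves on 4-methoxyphenyl, with a 2.1-fold lower number from compound 1 to compound 4 (0.32 log units; beyond the scatter) as the step, so growth inhibition at this place does not need a six-membered aromatic ring, though only a single such replacement is shown. Compound 2 stands at a limit, so an at least 9.2-fold lower number from compound 2 to compound 4 (0.96 log units; beyond the scatter) as a step gives a bound and not a size: the limit of > 100000 nM in this assay, at which 1 of the 4 values shown sits.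

As far as these compounds go, whether the lead of compound 3 follows from its chlorine or from its phenyl ring stays open, since no unsubstituted phenyl sits in this place. Also open, from the compounds shown here alone, is how a furan-2-yl or pyridin-3-yl ring, or a thiophen-2-yl carrying a chlorine, would compare with compound 3 and compound 4.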